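This account rests on a few compounds, and the source may have more. Where it says the series, first, only, none or still open, it means among the compounds named here.

Three analogues on a shared core have been run in an assay on isolated protein for inhibition of Maltase-glucoamylase (Homo sapiens), with a stated time of 15 min; a higher number here means a weaker inhibitor, a lower number a stronger inhibitor. Compound 1 `O=C(N/N=C/c1cccs1)c1ccc(-c2nc3ccccc3s2)cc1` gives 8480 nM in this assay. Compound 2 `O=C(N/N=C/c1cccc(O)c1O)c1ccc(-c2nc3ccccc3s2)cc1` gives 11200 nM in this assay, and compound 3 `COc1ccc(/C=N/NC(=O)c2ccc(-c3nc4ccccc4s3)cc2)c(O)c1` gives 6970 nM in this assay. Compound 3 carries the lowest of the three numbers, but its gaps to the others stay inside the scatter: a 1.2-fold lower number from compound 1 to compound 3 (0.09 log units; within the scatter) and a 1.6-fold lower number from compound 2 to compound 3 (0.21 log units; within the scatter). The step of a 1.3-fold higher number from compound 1 to compound 2 (0.12 log units; within the scatter) is equally flat.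

Compound 4 `O=C(N/N=C/c1ccc(O)c(O)c1)c1ccc(-c2nc3ccccc3s2)cc1` is still to be measured. The change is 3,4-dihydroxyphenyl in place of 2-hydroxy-4-methoxyphenyl on a carbon with a double bond to nitrogen. Within the data shown here, the steps that bear on it are the three that already exchange one aryl group on that same carbon, a 1.3-fold higher number from compound 1 to compound 2 (0.12 log units; within the scatter), a 1.2-fold lower number from compound 1 to compound 3 (0.09 log units; within the scatter) and a 1.6-fold lower number from compound 2 to compound 3 (0.21 log units; within the scatter), none of which left the scatter. Among the measured compounds shown here, the 2,3-dihydroxyphenyl of compound 2 is the closest precedent, and it sits within scatter of compound 1 and compound 3. No step beyond the scatter is therefore expected in this assay for compound 4, and the estimated step is a 1.1-fold higher number from compound 3 to compound 4 (0.06 log units; within the scatter). Compound 4 is expected to give about 8000 nM in this assay, with a range from 4000 nM to 16000 nM.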

Compound 4, half-maximal inhibitory concentration: 15100 nM
Compound 4: middle estimate off by 1.9-fold (0.28 log units), on the low side; measured number inside the range.
By their numbers in this assay, from the lowest: compounds 3, 1, 2 and 4 (each within the scatter of the next, the first and the last beyond it).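

In this assay, the aryl group on a carbon with a double bond to nitrogen now gives its first step beyond the scatter (a 2.2-fold higher number from compound 3 to compound 4 (0.34 log units; beyond the scatter)) with 3,4-dihydroxyphenyl in place of 2-hydroxy-4-methoxyphenyl. The position is therefore not entirely flat, although the other two new steps stay within the scatter: 3,4-dihydroxyphenyl in place of 2,3-dihydroxyphenyl gives (a 1.3-fold higher number from compound 2 to compound 4 (0.13 log units; within the scatter)) and 3,4-dihydroxyphenyl in place of thiophen-2-yl gives (a 1.8-fold higher number from compound 1 to compound 4 (0.25 log units; within the scatter)) so only the two ends of the series separate. No measured evidence bears on the origin of this step.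

The compounds shown do not separate the loss of the methoxy group from the changed placement of the hydroxyl groups. From the compounds shown here alone, the effect of an aminophenyl group, a carboxyphenyl group or a longer alkyl chain on this carbon remains open.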